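The compounds below may be only part of what the source reports. "The series", "measured", "known", "first", "only" and "open" are said of these compounds alone.

Compound 1 `CC#CC(CC(=O)O)c1ccc(OCc2ccc(C(=O)N3CCN(C)CC3)s2)cc1` shows the shared core of this small set, carrying a methyl on an amine nitrogen in a ring. In a functional assay on HEK293 cells for agonist activity at Free fatty acid receptor 1 (Homo sapiens), read by fluorescence and calcium flux (on this read-out lower numbers stand for an effect already at smaller amounts and higher numbers for an effect only at larger amounts of compound), compound 1 gives only a limit of the assay, > 5000 nM. Compound 2 `CC#CC(CC(=O)O)c1ccc(OCc2ccc(C(=O)N3CCN(c4ccncc4)CC3)s2)cc1` carries pyridin-4-yl in that place. In this assay compound 2 likewise gives only a limit, > 5000 nM. Compound 2 thus stands at the limit of > 5000 nM in this assay, at which 2 of the 3 values shown sit, so its position among the numbers is not fixed. The step from compound 1 to compound 2 is accordingly a step that the two limits leave unreadable from compound 1 to compound 2. Compound 3 `CC#CC(CC(=O)O)c1ccc(OCc2ccc(C(=O)N3CCN(c4ccc([N+](=O)[O-])cc4)CC3)s2)cc1` carries 4-nitrophenyl on the same nitrogen, and in this assay compound 3 gives 231 nM. This yields an at least 21-fold lower number from compound 1 to compound 3 (1.33 log units; beyond the scatter) and an at least 21-fold lower number from compound 2 to compound 3 (1.33 log units; beyond the scatter).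

Compound 4 `CC#CC(CC(=O)O)c1ccc(OCc2ccc(C(=O)N3CCN(c4cccc([N+](=O)[O-])c4)CC3)s2)cc1` has not yet been measured. It differs from compound 2 in this way: 3-nitrophenyl in place of pyridin-4-yl on an amine nitrogen in a ring. The only measured step that bears on it is an at least 21-fold lower number from compound 2 to compound 3 (1.33 log units; beyond the scatter), in which the entering group was 4-nitrophenyl rather than 3-nitrophenyl; how moving the nitro group within the phenyl ring matters is not shown by any measured pair. Compound 4 is therefore expected to follow a step of an at least 10-fold lower number from compound 2 to compound 4 (1.00 log units; beyond the scatter), in the direction of a lower number, with broad uncertainty. The estimate for compound 4 in this assay is 500 nM, between 150 nM and 3000 nM.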

Compound 4, half-maximal effective concentration: 187 nM
Estimate against measurement, compound 4: 2.7-fold (0.43 log units) above; low and high end bracket the measured number.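

In this assay, the nitro group proves not to be tied to the place it holds in 4-nitrophenyl: exchanging that group for 3-nitrophenyl on the amine nitrogen in a ring gives a 1.2-fold lower number from compound 3 to compound 4 (0.09 log units; within the scatter), so the two nitrophenyl groups cannot be told apart on this read-out. The large step seen earlier is thus not confined to a single group, since 3-nitrophenyl also gives an at least 26-fold lower number from compound 2 to compound 4 (1.42 log units; beyond the scatter) and an at least 26-fold lower number from compound 1 to compound 4 (1.42 log units; beyond the scatter). Compound 2 gives only a limit, so the true size of the step from compound 2 stays a bound rather than a measured distance: the limit of > 5000 nM in this assay, at which 2 of the 4 values shown sit.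

The compounds shown do not separate the phenyl ring from its nitro group, so it stays open what an unsubstituted phenyl, or a nitrile or a methoxy group in place of the nitro group, would give at this position. Also open, on these data alone, is whether a benzyl group on the same nitrogen would keep a number in the range of compound 3 and compound 4.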